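Changing the aryl group on a shared core

The source may hold more compounds than are shown below. What is called first, only, known or untested is meant among the compounds shown, and "the series" means these compounds.

Compound 1 `COc1ccccc1C1C(C#N)=C(N)N(c2ccc(S(N)(=O)=O)cc2)C2=C1C(=O)CCC2` gives 0% in a functional assay on Ehrlich cells (Mus musculus) for antiproliferative activity, read by trypan blue exclusion, with a stated time of 2 h, tested at 50 ug/mL; on this read-out lower numbers stand for a weaker effect and higher numbers for a stronger effect at the one concentration tested.
Compound 2 `COc1ccc(C2C(C#N)=C(N)N(c3ccc(S(N)(=O)=O)cc3)C3=C2C(=O)CCC3)cc1` gives 90% in this assay.
Compound 3 `COc1ccc2ccccc2c1C1C(C#N)=C(N)N(c2ccc(S(N)(=O)=O)cc2)C2=C1C(=O)CCC2` gives 70% in this assay.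

Compound 1 stands lowest of the three measured numbers in this assay; its nearest neighbour is compound 3, and compound 2 lies furthest from it. Compound 4 `COc1ccc(C2C(C#N)=C(N)N(c3ccc(S(N)(=O)=O)cc3)C3=C2C(=O)CCC3)c2ccccc12` has not yet been measured. The change from compound 1 to compound 4 is 4-methoxynaphthalen-1-yl in place of 2-methoxyphenyl on a saturated ring carbon.

For the measured compounds named here, two measured steps bear on this change. The step of a number 90 percentage points higher from compound 1 to compound 2 (beyond the scatter) shows the effect of moving the methoxy group to the 4-position of the phenyl ring. The step of a number 70 percentage points higher from compound 1 to compound 3 (beyond the scatter) shows the effect of enlarging the 2-methoxyphenyl group to a 2-methoxynaphthalen-1-yl group. Compound 4 joins both features in a 4-methoxynaphthalen-1-yl group. The step of a number 20 percentage points lower from compound 2 to compound 3 (beyond the scatter) suggests that the second ring alone does not carry the whole gain, so the position of the methoxy group matters. A large rise beyond the scatter is therefore expected for compound 4, estimated as a number 80 percentage points higher from compound 1 to compound 4 (beyond the scatter). Compound 4 is expected to give about 80% in this assay, with an estimated range from 55% to 98%.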

Compound 4, a percentage reported as activity, at one concentration (the size of the read-out at that concentration, not a potency): 30%
Beside the measured number, compound 4's estimate is 50 percentage points above it; the measured number lies below the stated range.
By their numbers in this assay, from the lowest: compound 1; then compound 4; then compound 3; then compound 2.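

In this assay, the 4-methoxynaphthalen-1-yl group keeps only part of the gain over 2-methoxyphenyl, with a number 30 percentage points higher from compound 1 to compound 4 (beyond the scatter), while it falls well short of both single-feature groups, with a number 60 percentage points lower from compound 2 to compound 4 (beyond the scatter) and a number 40 percentage points lower from compound 3 to compound 4 (beyond the scatter). The two changes at this saturated ring carbon therefore do not add up, and the direction of each depends on the other: with one aromatic ring, the 4-methoxy group gives the higher number, a number 90 percentage points higher from compound 1 to compound 2 (beyond the scatter), whereas with two aromatic rings the 2-methoxy group does. Nothing available here accounts for this reversal.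

The four compounds leave open whether the reversal belongs to the methoxy group itself, or whether a hydroxy group, a chlorine atom or a dimethylamino group in its place on the same aryl groups would show the same dependence on the second ring. Since each number comes from one concentration, they also leave open how the compounds would rank across a range of concentrations.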